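The source may hold more compounds than are shown below. What is called first, only, known or untested is meant among the compounds shown, and "the series" means these compounds.

Measured compounds:
- compound 1, `Cc1cc(S(=O)(=O)/N=C(\N)n2nccc2-c2ccccc2)c(SCc2ccc(C(F)(F)F)cc2)cc1Cl`: in a functional assay on HCT-116 cells (Homo sapiens) for cytotoxicity, read by MTT assay, with a stated time of 72 h (a higher number here means a weaker inhibitor, a lower number a stronger inhibitor), compound 1 gives 14000 nM
- compound 2, `Cc1cc(S(=O)(=O)/N=C(\N)n2nccc2-c2ccccc2)c(SCc2ccccc2C)cc1Cl`: in this assay compound 2 gives 16000 nM
- compound 3, `Cc1cc(S(=O)(=O)/N=C(\N)n2nccc2-c2ccccc2)c(SCc2cccc3ccccc23)cc1Cl`: in this assay compound 3 gives 7000 nM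

Compound 3 has the lowest number of the three, but its step to compound 1 is within the scatter, since a 2.0-fold lower number from compound 1 to compound 3 (0.30 log units; within the scatter); only its step from compound 2 is beyond it, a 2.3-fold lower number from compound 2 to compound 3 (0.36 log units; beyond the scatter). By contrast a 1.1-fold higher number from compound 1 to compound 2 (0.06 log units; within the scatter). Compound 4, `Cc1cc(S(=O)(=O)/N=C(\N)n2nccc2-c2ccccc2)c(SCc2ccccc2C(F)(F)F)cc1Cl`, has not yet been measured. It differs from compound 3 in one place: 2-(trifluoromethyl)phenyl in place of naphthalen-1-yl on a saturated chain carbon bound to a sulfur. The two steps that bear on this are the ones that exchanged a substituted phenyl for naphthalen-1-yl at the same place, and both went toward lower numbers by roughly the same modest amount. Reversing that direction, the number for compound 4 is expected to rise by a 2.0-fold higher number from compound 3 to compound 4 (0.30 log units; within the scatter), an estimate that lies within the scatter of compound 3. Compound 4 is therefore estimated at 14000 nM, within a range from 6000 nM to 32000 nM.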

Compound 4, half-maximal inhibitory concentration: 16000 nM
For compound 4 the middle estimate is 1.1-fold (0.06 log units) below the measured one, and the stated range covers the measured number.
By their numbers in this assay, from the lowest: compounds 3, 1, 2 and 4 (each within the scatter of the next, the first and the last beyond it).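

In this assay, 2-(trifluoromethyl)phenyl in place of naphthalen-1-yl on a saturated chain carbon bound to a sulfur gives a 2.3-fold higher number from compound 3 to compound 4 (0.36 log units; beyond the scatter), so naphthalen-1-yl now stands beyond the scatter from two of the three substituted phenyl compounds, though not from compound 1. The exchanges among the substituted phenyl groups separate nothing at this place: trifluoromethyl in place of methyl on an aromatic carbon gives no change at the digits printed from compound 2 to compound 4 (within the scatter), and 2-(trifluoromethyl)phenyl in place of 4-(trifluoromethyl)phenyl gives a 1.1-fold higher number from compound 1 to compound 4 (0.06 log units; within the scatter). Nothing available explains these steps.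

All the groups shown at this place are carbon aromatic rings carrying methyl or trifluoromethyl, or the fused naphthalen-1-yl. As far as these compounds go, how naphthalen-2-yl, a phenyl ring bearing an amine or a carboxylic acid, or a longer chain in place of the saturated chain carbon would read in this assay remains open.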